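The source may hold more compounds than are shown below. What is called first, only, known or untested is meant among the compounds shown, and "the series" means these compounds.

Compound 1 `Cn1nc(C(F)(F)F)cc1C(=O)Nc1ccc(S(=O)(=O)c2ccccc2CO)cc1` opens the pair. In an ADME assay on Vero cells (Chlorocebus sabaeus) for cytotoxicity, read by MTT assay, with a stated time of 24 h (on this read-out higher numbers stand for lower toxicity in this test and lower numbers for higher toxicity in this test), compound 1 returns only a limit, > 75000 nM. Compound 2 `Cn1nc(C(F)(F)F)cc1C(=O)Nc1ccc(S(=O)(=O)N2CCCCC2)cc1` carries piperidin-1-yl in place of 2-(hydroxymethyl)phenyl on the sulfonyl sulfur. In this assay compound 2 likewise returns only a limit, > 75000 nM. The step that the two limits leave unreadable from compound 1 to compound 2 stays unreadable; every measured value sits at the limit of > 75000 nM in this assay, at which 2 of the 2 values shown sit. Compound 3 `Cn1nc(C(F)(F)F)cc1C(=O)Nc1ccc(S(=O)(=O)c2ccccc2)cc1` differs from compound 1 by hydrogen in place of hydroxymethyl on an aromatic carbon. Only the unreadable step bears on this change, so no step beyond the scatter is expected. Compound 3 is estimated at 100000 nM, within 75000 nM to 200000 nM. The step that the limit leaves unreadable from compound 1 to compound 3 is the expected outcome.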

Compound 3, half-maximal cytotoxic concentration in the Vero assay: > 75000 nM
Compound 3 ended at the assay's limit; the forecaster's own chance of this, stated with the estimate: 90%; the middle value is on the limit's open side.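

Among the compounds shown here, compound 1, compound 2 and compound 3 all sit at a limit in the Vero assay, so no step among them can be read: the limit of > 75000 nM in the Vero assay, at which 3 of the 3 values shown sit. In a physicochemical assay for solubility, read by nephelometry, at pH 7.4 (a higher number here means a more soluble compound, a lower number a less soluble compound), compound 1 gives 46 ug/mL and compound 3 gives 22 ug/mL. Which change, if any, would bring a value in the Vero assay off the limit stays open.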